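A few compounds are considered here, and "the series" means these few. Any claim that something is new, unique, unknown or untested is made for them only; others in the source may bear on it.

Measured compounds in a functional assay on MDA-MB-231 cells (Homo sapiens) for antiproliferative activity, read by MTT assay, with a stated time of 24 h; on this read-out higher numbers stand for weaker inhibition and lower numbers for stronger inhibition:
Compound 1 `O=C1NC(O)(CCn2cc(C3=CCCCC3)nn2)C(OCc2ccccc2)=C1OCc1ccccc1` gives 13100 nM
Compound 2 `CC(C)(C)c1ccc(-c2cn(C/C=C3\OC(=O)C(OCc4ccccc4)=C3OCc3ccccc3)nn2)cc1` gives 51200 nM
Compound 3 `COC1=C(OC)C(O)(CCn2cc(-c3ccccc3)nn2)NC1=O` gives 18300 nM

Among these three, compound 1 gives the lowest number in this assay. Compound 3 lies nearest to it, with a number higher by an amount that falls within the usual scatter, so the two cannot be set in order. Compound 2 gives the highest number, and its distance from compound 1 lies beyond the scatter, so compound 2 is the weaker of that pair.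

Compound 4 `O=C1NC(O)(CCn2cc(Cc3ccccc3)nn2)C(OCc2ccccc2)=C1OCc1ccccc1` has not yet been measured in this assay. It shares its core with compound 1 and differs from it in one place: benzyl in place of cyclohex-1-en-1-yl on an aromatic carbon. Among the measured compounds no pair differs by this change alone, so no measured step can be carried over to it, and nothing here tells how a benzyl behaves against a cyclohex-1-en-1-yl at this place. With the core of compound 1 unchanged, the step of a 1.1-fold higher number from compound 1 to compound 4 (0.03 log units; within the scatter) is expected to be small, in no firm direction, and likely within the scatter. On that basis compound 4 is estimated at 14000 nM in this assay, with a range from 5000 nM to 40000 nM.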

Compound 4, half-maximal inhibitory concentration: > 100000 nM
Compound 4 ended at the assay's limit; the forecaster's own chance of this, stated with the estimate: 10%; at least 7.1-fold (0.85 log units) between middle value and limit.
By their numbers in this assay, from the lowest: compounds 1 and 3 (each within the scatter of the next); then compound 2. At a limit, above all of these: compound 4.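

In this assay, the aromatic carbon of the five-membered aromatic ring with 3 nitrogen proves sensitive to the group it carries: with the core of compound 1 unchanged, benzyl in place of cyclohex-1-en-1-yl gives an at least 7.6-fold higher number from compound 1 to compound 4 (0.88 log units; beyond the scatter), the first step measured at this place. Compound 4 gives > 100000 nM, which is a limit of the assay and not a number, so the size of this step is known only as a lower bound: the limit of > 100000 nM in this assay, at which 1 of the 4 values shown sits. Both groups consist of carbon only, with no hydrogen-bond donors or acceptors and no net charge, so a change confined to carbon groups is enough at this place to move the number beyond the scatter.

The compounds shown do not separate the aromatic ring of benzyl from its extra carbon, as neither a phenyl nor a cyclohexylmethyl group on the core of compound 1 appears among them. They also leave open how a group carrying an amine or a carboxylic acid would behave at this place.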